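Swapping the halogenated phenyl ring on the triazole of compound 1

This account rests on a few compounds, and the source may have more. Where it says the series, first, only, none or still open, it means among the compounds named here.

Compound 1 `CC1(C)[C@H]2CC[C@]1(C)N(Cc1cn(-c3ccc(Cl)cc3)nn1)C(=O)C2` is tested in a functional assay on OVCAR-3 cells (Homo sapiens) for inhibition, read by MTT assay, with a stated time of 24 h (on this read-out lower numbers stand for stronger inhibition and higher numbers for weaker inhibition), where it gives 160 nM. Going by the values given here, of the three compounds measured so far, compound 1 has the highest number. Compound 2 `COc1ccccc1-n1cc(CN2C(=O)C[C@@H]3CC[C@@]2(C)C3(C)C)nn1` gives 140 nM in this assay, and the step of a 1.1-fold lower number from compound 1 to compound 2 (0.06 log units; within the scatter) lies within the scatter. Compound 3 `Cc1ccc(-n2cc(CN3C(=O)C[C@@H]4CC[C@@]3(C)C4(C)C)nn2)cc1` gives 40 nM, and the step of a 4.0-fold lower number from compound 1 to compound 3 (0.60 log units; beyond the scatter) is a modest improvement, as is the step of a 3.5-fold lower number from compound 2 to compound 3 (0.54 log units; beyond the scatter).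

Compound 4 `CC1(C)[C@H]2CC[C@]1(C)N(Cc1cn(-c3cccc(F)c3)nn1)C(=O)C2` differs from compound 1 in one place: 3-fluorophenyl in place of 4-chlorophenyl on an aromatic nitrogen. Among the compounds with values here, the only step that touches the same group on an aromatic carbon is the one from compound 1 to compound 3, where methyl replaced chloro and the number fell modestly. Within the data shown here, exchanging one halogen for another while also moving it is a different kind of change, and the data give no direct precedent for it. On balance a step of a 1.3-fold lower number from compound 1 to compound 4 (0.12 log units; within the scatter) is expected, leaving compound 4 at an estimated 120 nM, with a range from 50 nM to 300 nM.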

Compound 4, half-maximal inhibitory concentration: 430 nM
Estimate against measurement, compound 4: 3.6-fold (0.55 log units) below; the whole stated range lies below it.
By their numbers in this assay, from the lowest: compound 3; then compounds 2 and 1 (each within the scatter of the next); then compound 4.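

Going by these compounds alone, the phenyl ring on the aromatic nitrogen can also cost activity: in this assay, a 2.7-fold higher number from compound 1 to compound 4 (0.43 log units; beyond the scatter) shows a modest loss, whereas no earlier step away from compound 1 raised the number beyond the scatter. Compound 4 is the weakest of the four, with a 3.1-fold higher number from compound 2 to compound 4 (0.49 log units; beyond the scatter) and an 11-fold higher number from compound 3 to compound 4 (1.03 log units; beyond the scatter), the latter being large and showing how much this one group can matter on an unchanged core. Nothing measured here explains why 3-fluorophenyl reads so much weaker than the other groups.

The step from 4-chlorophenyl to 3-fluorophenyl changes both the halogen and its place on the ring, and the compounds shown cannot tell these two changes apart. They also leave open how an unsubstituted phenyl, or a phenyl ring carrying an amine or a carboxylic acid, would read here.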